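This account rests on a few compounds, and the source may have more. Where it says the series, first, only, none or still open, it means among the compounds named here.

Compound 1 `COc1ccc(-n2cc(COc3ccc4oc(=O)ccc4c3)nn2)cc1` — 46800 nM in a functional assay on A549 cells (Homo sapiens) for cytotoxicity, read by MTT assay, with a stated time of 48 h; on this read-out higher numbers stand for weaker inhibition and lower numbers for stronger inhibition
Compound 2 `O=c1ccc2cc(OCc3cn(-c4cccc(CO)c4)nn3)ccc2o1` — 35100 nM in this assay
Compound 3 `O=c1ccc2cc(OCc3cn(-c4ccccc4[N+](=O)[O-])nn3)ccc2o1` — 10200 nM in this assay

Compound 3 gives the lowest number of the three measured compounds: compound 2 stands a step above it a 3.4-fold lower number from compound 2 to compound 3 (0.54 log units; beyond the scatter), and compound 1 further still a 4.6-fold lower number from compound 1 to compound 3 (0.66 log units; beyond the scatter). Compound 4 `COc1ccccc1-n1cc(COc2ccc3oc(=O)ccc3c2)nn1` differs from compound 3 in one place: methoxy in place of nitro on an aromatic carbon. Both measured steps that bear on this change point the same way, since swapping a 4-methoxyphenyl or a 3-(hydroxymethyl)phenyl for the 2-nitrophenyl lowered the number modestly. Undoing the nitro group, even with the methoxy placed differently than in compound 1, is therefore expected to raise the number again, by a 2.5-fold higher number from compound 3 to compound 4 (0.41 log units; beyond the scatter). Compound 4 is estimated at 26000 nM, within a range from 9000 nM to 75000 nM.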

Compound 4, half-maximal inhibitory concentration: 18700 nM
Beside the measured number, compound 4's estimate is 1.4-fold (0.14 log units) above it, within the range that was stated.
By their numbers in this assay, from the lowest: compounds 3, 4, 2 and 1 (each within the scatter of the next, the first and the last beyond it).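

In this assay, methoxy in place of nitro gives a 1.8-fold higher number from compound 3 to compound 4 (0.26 log units; within the scatter), so at this ring carbon the nitro group is not needed to reach this level of cytotoxicity. Having 2-methoxyphenyl in place of 4-methoxyphenyl gives a 2.5-fold lower number from compound 1 to compound 4 (0.40 log units; beyond the scatter), the first sign that the methoxy group's place on the ring matters, while 2-methoxyphenyl in place of 3-(hydroxymethyl)phenyl gives only a 1.9-fold lower number from compound 2 to compound 4 (0.27 log units; within the scatter). No evidence here explains these steps. Going by these compounds, how an amine or a carboxylic acid at this ring carbon would compare remains open.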